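The source may hold more compounds than are shown below. What is called first, only, known or untested is meant among the compounds shown, and "the series" means these compounds.

Measured so far:
compound 1 `Nc1cc(N)c2nc(-c3ccccc3)c(Oc3ccc(Cl)c(Cl)c3)nc2c1`: < 100000 nM
compound 2 `Nc1cc(N)c2nc(-c3ccccc3)c(NCc3ccc(Cl)c(Cl)c3)nc2c1`: 67600 nM

In a functional assay on UACC-62 cells (Homo sapiens) for inhibition, read by sulforhodamine B assay, with a stated time of 48 h (a lower number here means that less compound is tolerated, a higher number that more compound is tolerated), compound 1 gives < 100000 nM, which is a limit of the assay and not a number; it sits at the limit of < 100000 nM in this assay, at which 1 of the 2 values shown sits. Compound 2 gives 67600 nM in this assay. Among the compounds with values here, no step between measured compounds can be drawn, so the position of compound 1 is known only as that limit.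

Compound 3 `Nc1cc(N)c2nc(-c3ccccc3)c(Oc3ccc(F)cc3)nc2c1` carries the change (4-fluorophenyl in place of 3,4-dichlorophenyl on an oxygen on an aromatic ring). Nothing measured speaks to this replacement, and no shift beyond the usual scatter is expected; the step that the limit leaves unreadable from compound 1 to compound 3 is an estimate of essentially no change. Compound 3 is therefore expected near 70000 nM, between 20000 nM and 150000 nM.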

Compound 3, concentration lethal to 50% of the cells: 69200 nM
Beside the measured number, compound 3's estimate is 1.0-fold (0.00 log units) above it; the measured number falls inside the stated range.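

Compound 1 is known only as a limit of the assay, so no step from compound 1 to compound 3 can be read: the limit of < 100000 nM in this assay, at which 1 of the 3 values shown sits.

As far as these compounds go, whether 4-fluorophenyl in place of 3,4-dichlorophenyl shifts the value in this assay remains open.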